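This account rests on a few compounds, and the source may have more. Where it says the series, first, only, none or still open, it means among the compounds named here.

In a functional assay on SK-MEL-147 cells (Homo sapiens) for cytotoxicity, read by MTT assay, with a stated time of 24 h (on this read-out lower numbers stand for an effect already at smaller amounts and higher numbers for an effect only at larger amounts of compound), compound 1 (`CCCCC#Cc1cc(C(=O)OCC)nc2ccc(OC)cc12`), with butyl on a triple-bonded carbon, gives 7200 nM. Compound 2 (`CCOC(=O)c1cc(C#Cc2ccc(N)cc2)c2cc(OC)ccc2n1`), with 4-aminophenyl there instead, gives 8800 nM. For the measured compounds named here, the comparison is a 1.2-fold higher number from compound 1 to compound 2 (0.09 log units; within the scatter), so compound 2 stands level with the only other measured compound. Compound 3 (`CCOC(=O)c1cc(C#Cc2ccccc2[N+](=O)[O-])c2cc(OC)ccc2n1`) has not yet been measured. It carries 2-nitrophenyl in place of 4-aminophenyl on a triple-bonded carbon. Going by the values given here, only one measured step bears on this change, and it involves a different pair of groups, so it is a weak guide. That step, a 1.2-fold higher number from compound 1 to compound 2 (0.09 log units; within the scatter), gives no ground to expect a clear shift in either direction in this assay. The expected change is therefore no larger than the scatter: a 1.2-fold lower number from compound 2 to compound 3 (0.07 log units; within the scatter). For compound 3 the estimate is 7500 nM, with an expected range from 2500 nM to 20000 nM.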

Compound 3, half-maximal effective concentration: > 150000 nM
Compound 3: no number, only a limit (the forecaster's own chance of this, stated with the estimate: 10%); middle value at least 20-fold (1.30 log units) away from the limit.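

In this assay, the group on this triple-bonded carbon turns out to matter a great deal: butyl and 4-aminophenyl gave values level with each other, but 2-nitrophenyl gives an at least 17-fold higher number from compound 2 to compound 3 (1.23 log units; beyond the scatter), and measured against butyl it gives an at least 20-fold higher number from compound 1 to compound 3 (1.31 log units; beyond the scatter). The reading for compound 3 is a limit and not a number: the limit of > 150000 nM in this assay, at which 1 of the 3 values shown sits. Having a six-membered aromatic ring at this place does not by itself decide the outcome, since 4-aminophenyl and 2-nitrophenyl both contain one, yet only compound 3 stands apart.

The compounds shown cannot separate the nitro group from where it sits on the phenyl ring, which would take a pair such as 4-nitrophenyl against 4-aminophenyl. On these data alone, how an unsubstituted phenyl or a longer chain would read in this assay also remains open.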